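The compounds below may be only part of what the source reports. "The series", "measured", "known", "first", "only" and "open" are said of these compounds alone.

Measured so far in a functional assay on CHO-K1 cells for antagonist activity at transient receptor potential cation channel subfamily V member 1 (Homo sapiens), read by FLIPR; on this read-out higher numbers stand for weaker inhibition and lower numbers for stronger inhibition:

compound 1 `CC1CCC(Nc2nc(C(F)(F)F)ccc2CNC(=O)C(C)c2ccc(NS(C)(=O)=O)c(F)c2)CC1` gives 27.2 nM
compound 2 `CC(C(=O)NCc1ccc(C(F)(F)F)nc1NCc1ccc(Cl)cc1)c1ccc(NS(C)(=O)=O)c(F)c1` gives 65.7 nM
compound 3 `CC(C(=O)NCc1ccc(C(F)(F)F)nc1N1CCC(c2ccccc2)CC1)c1ccc(NS(C)(=O)=O)c(F)c1` gives 0.6 nM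

Compound 2 gives the highest number of the three, with compound 1 nearest at a 2.4-fold higher number from compound 1 to compound 2 (0.38 log units; beyond the scatter) and compound 3 furthest at a 110-fold lower number from compound 2 to compound 3 (2.04 log units; beyond the scatter). Compound 4 `CC(=O)OC1CCN(c2nc(C(F)(F)F)ccc2CNC(=O)C(C)c2ccc(NS(C)(=O)=O)c(F)c2)CC1` arises from compound 2 through one change: 4-acetoxypiperidin-1-yl in place of (4-chlorobenzyl)amino on an aromatic carbon. The step that bears most on this change is the one in which the same kind of group, a piperidin-1-yl ring on that aromatic carbon, enters: a 110-fold lower number from compound 2 to compound 3 (2.04 log units; beyond the scatter); the parallel step a 45-fold lower number from compound 1 to compound 3 (1.66 log units; beyond the scatter) points the same way. Both large, both towards stronger inhibition. The group entering compound 4 carries an acetoxy rather than a phenyl on its ring, so a step of the same direction but smaller size is expected in this assay, an 8.2-fold lower number from compound 2 to compound 4 (0.91 log units; beyond the scatter). Compound 4 is therefore estimated at 8 nM, within a range of 1.5 nM to 40 nM.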

Compound 4, inhibition constant: 4 nM
Compound 4: the middle estimate sits 2.0-fold (0.30 log units) above what was measured; low and high end bracket the measured number.
By their numbers in this assay, from the lowest: compound 3; then compound 4; then compound 1; then compound 2.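

In this assay, the stronger inhibition seen with a ring nitrogen on this aromatic carbon does not need the phenyl of compound 3: 4-acetoxypiperidin-1-yl also lowers the number, with a 16-fold lower number from compound 2 to compound 4 (1.22 log units; beyond the scatter) and a 6.8-fold lower number from compound 1 to compound 4 (0.83 log units; beyond the scatter). What the ring carries still matters, as acetoxy in place of phenyl on a saturated ring carbon gives a 6.7-fold higher number from compound 3 to compound 4 (0.82 log units; beyond the scatter). No measurement here accounts for these steps.

Open, going by these compounds, is where an unsubstituted piperidin-1-yl ring would fall, and whether a hydroxyl or an amine on that ring carbon would sit nearer compound 3 or compound 4.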